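This account rests on a few compounds, and the source may have more. Where it says the series, first, only, none or still open, it means among the compounds named here.

Three analogues sharing one core have been tested in a functional assay on HGC-27 cells (Homo sapiens) for cytotoxicity, read by MTT assay, with a stated time of 72 h; a higher number here means a weaker inhibitor, a lower number a stronger inhibitor. Compound 1 `FC(F)(F)c1ccc(CSc2nc(Nc3ccccc3Cl)c3ccccc3n2)cc1` gives > 50000 nM in this assay, which is a limit of the assay rather than a number. Compound 2 `COc1ccccc1Nc1nc(SCc2ccc(C(F)(F)F)cc2)nc2ccccc12` gives > 50000 nM, again only a limit. Compound 3 `COc1ccc(Nc2nc(SCc3ccc(C(F)(F)F)cc3)nc3ccccc23)c(OC)c1` gives > 50000 nM, also a limit. The steps a step that the two limits leave unreadable from compound 1 to compound 2, a step that the two limits leave unreadable from compound 1 to compound 3 and a step that the two limits leave unreadable from compound 2 to compound 3 therefore cannot be sized, since (the limit of > 50000 nM in this assay, at which 3 of the 3 values shown sit). As far as these compounds go, compound 4 `COc1cc(Nc2nc(SCc3ccc(C(F)(F)F)cc3)nc3ccccc23)cc(OC)c1` is untested; it differs from compound 2 by 3,5-dimethoxyphenyl in place of 2-methoxyphenyl on a nitrogen on an aromatic ring. Within the data shown here, no measured step shows a readable size, so no shift beyond the scatter is expected in either direction, and compound 4 is expected to sit around 60000 nM, between 20000 nM and 200000 nM, most probably reported once more as a limit. This estimate amounts to an expected step that the limit leaves unreadable from compound 2 to compound 4.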

Compound 4, half-maximal inhibitory concentration: > 50000 nM
Compound 4: a limit, no number; the forecaster's own chance of this, stated with the estimate: 85%; the middle value does not contradict the limit.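

Compound 4 gives > 50000 nM, again a limit and not a number. No step linking compound 1, compound 2 or compound 3 with compound 4 can therefore be read: the limit of > 50000 nM in this assay, at which 4 of the 4 values shown sit.

The compounds shown leave open whether any group on this nitrogen of the shared core would give a readable value.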